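The source may hold more compounds than are shown below. What is called first, only, known or untested is meant among the compounds shown, and "the series" means these compounds.

For the measured compounds named here, in a functional assay on K562 cells (Homo sapiens) for cytotoxicity, read by MTT assay, with a stated time of 24 h (on this read-out higher numbers stand for weaker inhibition and lower numbers for stronger inhibition), compound 2 `CN1C/C(=C\c2ccc(C#N)cc2)C(=O)/C(=C/c2ccccc2F)C1` gives 2670 nM, the lowest of the two numbers so far. Compound 1 `CN1C/C(=C\c2ccc(C(F)(F)F)cc2)C(=O)/C(=C/c2ccccc2F)C1` gives 6340 nM. Going by the values given here, the single measured step, a 2.4-fold lower number from compound 1 to compound 2 (0.38 log units; beyond the scatter), concerns a different place in the shared core. Compound 3 `CN1C/C(=C\c2ccc(C#N)cc2)C(=O)/C(=C/c2ccc(Cl)cc2Cl)C1` differs from compound 2 by 2,4-dichlorophenyl in place of 2-fluorophenyl on a double-bonded chain carbon bound to a double-bonded ring carbon. Among the compounds with values here, no measured step touches this change, so nothing in the data points in either direction. The expected step is therefore a 1.1-fold lower number from compound 2 to compound 3 (0.03 log units; within the scatter), nothing beyond the scatter, with a wide range. For compound 3 the estimate is 2500 nM, between 800 nM and 8000 nM.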

Compound 3, half-maximal inhibitory concentration: 11900 nM
Beside the measured number, compound 3's estimate is 4.8-fold (0.68 log units) below it; the measured number lies above the stated range.
By their numbers in this assay, from the lowest: compound 2; then compounds 1 and 3 (each within the scatter of the next).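

In this assay, swapping 2-fluorophenyl for 2,4-dichlorophenyl on a double-bonded chain carbon bound to a double-bonded ring carbon brings a 4.5-fold higher number from compound 2 to compound 3 (0.65 log units; beyond the scatter) and so weaker inhibition. This position therefore also moves the read-out, whereas the earlier step concerned only a different place in the shared core. Nothing measured here accounts for this step.

The compounds shown leave open whether a single chlorine, a plain phenyl or a phenyl carrying a methoxy group or an amine would retain the number of compound 2. They also leave open whether this swap would give a step of similar size with trifluoromethyl in place of cyano.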